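The source may hold more compounds than are shown below. What is called first, only, known or untested is meant among the compounds shown, and "the series" means these compounds.

Working notes on the series. From the compounds shown here alone, compound 1 `Clc1ccc2c(NCCn3cnc4c(N5CCCCC5)nc(Cl)nc43)ccnc2c1` and compound 2 `CN(C)c1nc(Cl)nc2c1ncn2CCCNc1ccnc2cc(Cl)ccc12` are the measured members so far, and compound 3 `Clc1ccc2c(NCCCn3cnc4c(N5CCCC5)nc(Cl)nc43)ccnc2c1` is still open. In an ADME assay on Vero cells (Chlorocebus sabaeus) for cytotoxicity, read by neutral red uptake, with a stated time of 48 h (a higher number here means a weaker inhibitor, a lower number a stronger inhibitor), compound 1 gives > 10700 nM, which is a limit and not a number. In this assay compound 2 gives > 11400 nM, which is also a limit and not a number. Compound 2 therefore has no exact reading, and the only other result available is a limit too.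

Compound 3 carries pyrrolidin-1-yl in place of the dimethylamino of compound 2 on an aromatic carbon (pyrrolidin-1-yl in place of dimethylamino on an aromatic carbon). Within the data shown here, no step between measured compounds is available to size this change, so no shift beyond the usual scatter is expected in this assay, in either direction. This expectation rests on compound 2 with its limit of > 11400 nM, and it remains a weak basis. The expected step that the limit leaves unreadable from compound 2 to compound 3 is correspondingly small. For compound 3 the estimated value is 14000 nM, with an expected range of 7000 nM to 30000 nM, and a report as a limit is the likelier outcome.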

Compound 3, half-maximal inhibitory concentration: > 10700 nM
Compound 3 ended at the assay's limit; the forecaster's own chance of this, stated with the estimate: 75%; the middle value is on the limit's open side.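

The results for compound 2 and compound 3 are both limits and not numbers, so the step between them, pyrrolidin-1-yl in place of dimethylamino on an aromatic carbon, cannot be read. The compounds shown leave open where any of them would give an exact reading in this assay, and whether that change shifts it at all.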